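A few compounds are considered here, and "the series" means these few. Any claim that something is new, unique, unknown or untested is made for them only; others in the source may bear on it.

Measured so far:
- Compound 1 `N#Cc1ccc(-c2cs/c(=N/NC(=O)CSc3ncccn3)n2-c2ccccc2)cc1`: "not determined" (no result reported)
- Compound 2 `Cc1nnc(SCC(=O)N/N=c2/scc(-c3ccc(Cl)cc3)n2-c2ccccc2)s1`: 28 ug/mL
- Compound 3 `O=C(CSc1ncccn1)N/N=c1/scc(-c2ccccc2)n1-c1ccccc1`: "not determined" (no result reported)

These three entries come from a functional assay on C6 cells (Rattus norvegicus) for cytotoxicity, read by MTT assay, with a stated time of 24 h; on this read-out lower numbers stand for stronger inhibition and higher numbers for weaker inhibition. Only one of them is a real number, so the picture is thin. Compound 3 cannot be placed on any scale, since the entry for compound 3 is "not determined" (no result reported). It shares that gap with compound 1, and so it cannot be ranked against compound 2.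

The next compound to be tested is compound 4 `O=C(CSc1ncccn1)N/N=c1/scc(-c2ccc(Cl)cc2)n1-c1ccccc1`. The structural change is chloro in place of hydrogen on an aromatic carbon, para to a large group, or phenyl to 4-chlorophenyl when the same difference is cut one bond further out.

Among the compounds with values here, no pair of measured compounds shows what such a swap does in this assay, and without a starting number for compound 3 no step can be calculated. A small move toward stronger inhibition is the expectation, but this is a cautious guess and the data do not establish it. Within the data shown here, the only anchor is compound 2 at 28 ug/mL, so the estimate stays close to that figure and carries a wide range. For compound 4 the expected value is 25 ug/mL, with an estimated range of 8 ug/mL to 80 ug/mL.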

Compound 4, half-maximal inhibitory concentration: 83.3 ug/mL
Compound 4: middle estimate off by 3.3-fold (0.52 log units), on the low side, outside the stated range (above it).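

Within the data shown here, the one comparison now possible in this assay concerns the group on the sulfur, not the chloro. Both compounds carry the 4-chlorophenyl, and pyrimidin-2-yl in place of 5-methyl-1,3,4-thiadiazol-2-yl gives a 3.0-fold higher number from compound 2 to compound 4 (0.47 log units; beyond the scatter) on this read-out, a modest move toward weaker inhibition, so for this one pair the group on the sulfur is not a silent part of the structure. The change from phenyl to 4-chlorophenyl itself cannot be read, as compound 3 has only the entry "not determined" (no result reported) to start from, and nothing measured here gives a reason for the step on the sulfur.

On these data alone, what the chloro contributes on its own remains open, and so does the question of whether the step seen on the sulfur would have the same size with a plain phenyl in place of the 4-chlorophenyl. As far as these compounds go, it is also open how a fluoro or a methoxy group would read in place of the chloro, or how a simple amine would read in place of the aromatic ring on the sulfur.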